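A few compounds are considered here, and "the series" means these few. Any claim that something is new, unique, unknown or untested is made for them only; others in the source may bear on it.

Of the compounds shown here, three built on one shared core have been measured in a functional assay on MIA PaCa-2 cells (Homo sapiens) for inhibition, read by MTT assay, with a stated time of 48 h, tested at 10 uM; a lower number here means less inhibition of growth, a higher number more inhibition of growth at the concentration tested. Compound 1 `Cc1cc(=O)c2c(O)c(CN3CCC(N4CCCCC4)CC3)c(O)c([C@H]3CCN(C)C[C@H]3O)c2o1` gives 23%, compound 2 `Cc1cc(=O)c2c(O)c(CN3CCC(Cc4ccccc4)CC3)c(O)c([C@H]3CCN(C)C[C@H]3O)c2o1` gives 18%, and compound 3 `Cc1cc(=O)c2c(O)c(CN(C)CC(=O)O)c(O)c([C@H]3CCN(C)C[C@H]3O)c2o1` gives 16%. Compound 2 thus stands among three numbers that all lie within the usual scatter of one another, so these data do not rank the three compounds.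

The next compound to consider is compound 4 `Cc1cc(=O)c2c(O)c(CN3CCC(c4ccccc4)CC3)c(O)c([C@H]3CCN(C)C[C@H]3O)c2o1`. It differs from compound 2 in one place, with phenyl in place of benzyl on a saturated ring carbon.

Among the measured compounds shown here, only one measured step involves this same ring carbon. That step is a number 5 percentage points lower from compound 1 to compound 2 (within the scatter), with benzyl in place of piperidin-1-yl. It exchanged two quite different groups, yet its size stayed within the scatter. The change to compound 4 swaps two closely related groups, although a single step is thin evidence for any forecast. No step beyond the scatter is therefore expected in this assay, in either direction.

The expected step is no change at the digits printed from compound 2 to compound 4 (within the scatter), an estimate that stays within the scatter. For compound 4 the estimated value is 18%, with an expected range from 8% to 30%.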

Compound 4, percent growth inhibition at one concentration: 16%
Compound 4: the middle estimate sits 2 percentage points above what was measured; measured number inside the range.
By their numbers in this assay, from the lowest: compounds 3, 4, 2 and 1 (each within the scatter of the next).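

In this assay, the exchange of benzyl for phenyl on the saturated ring carbon, which takes the group from 7 heavy atoms to 6 while keeping its aromatic ring, gives a number 2 percentage points lower from compound 2 to compound 4 (within the scatter) and so adds a closely related pair to the earlier comparison of two very different groups. The listed step for phenyl in place of piperidin-1-yl is a number 7 percentage points lower from compound 1 to compound 4 (within the scatter) and, taken with the earlier step, it shows that piperidin-1-yl, benzyl and phenyl all lie within the scatter of one another at this position, so none of these three groups can be ranked above another. Nothing available here accounts for this flat result.

Still open, from the compounds shown here alone, is whether any group at this ring carbon can produce a step beyond the scatter, for example a primary amine, a carboxylic acid or a longer chain ending in phenyl, such as phenylpropyl. Also open, going by these compounds, is whether compounds that cannot be separated at this single tested concentration would separate in a full concentration series.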